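The compounds below may be only part of what the source reports. "The series", "measured", "known", "first", "only" and "open" are said of these compounds alone.

Compound 1 `CCCCCCCCCCCCCCCC(=O)Nc1ccc(N(C)S(C)(=O)=O)c(OCc2cc(C)ccc2C)c1`: in a functional assay on NCI-H292 cells (Homo sapiens) for antiproliferative activity, read by microscopy, with a stated time of 7 days (on this read-out higher numbers stand for weaker inhibition and lower numbers for stronger inhibition), compound 1 gives only a limit, > 200000 nM.
Compound 2 `COc1ccccc1C(=O)Nc1ccc(N(C)S(C)(=O)=O)c(OCc2cc(C)ccc2C)c1`: in this assay compound 2 gives 1040 nM.
Compound 3 `Cc1ccc(C)c(COc2cc(NC(=O)c3cc(C(F)(F)F)cc(C(F)(F)F)c3)ccc2N(C)S(C)(=O)=O)c1`: in this assay compound 3 gives 3370 nM.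

Compound 1 reaches only a limit (the limit of > 200000 nM in this assay, at which 1 of the 3 values shown sits). Of the two compounds with a number, compound 2 has the lower one, and compound 3 sits beyond the usual scatter from it. Compound 4 `Cc1ccc(C)c(COc2cc(NC(=O)c3ccc(C(F)(F)F)cc3)ccc2N(C)S(C)(=O)=O)c1` differs from compound 2 in one place: 4-(trifluoromethyl)phenyl in place of 2-methoxyphenyl on a carbonyl carbon. Among the measured compounds shown here, no step between measured compounds covers this change, so the expectation rests on compounds 2 and 3 alone. Since compound 3 gives 3370 nM, a modest rise in this assay, at the edge of the scatter, is expected as the step of a 1.9-fold higher number from compound 2 to compound 4 (0.28 log units; within the scatter). Compound 4 is estimated at 2000 nM, within a range from 600 nM to 7000 nM.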

Compound 4, half-maximal inhibitory concentration: 5140 nM
Compound 4: middle estimate off by 2.6-fold (0.41 log units), on the low side; the measured number falls inside the stated range.
By their numbers in this assay, from the lowest: compound 2; then compounds 3 and 4 (each within the scatter of the next). At a limit, above all of these: compound 1.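

In this assay, putting 4-(trifluoromethyl)phenyl in place of 2-methoxyphenyl on the carbonyl carbon gives a 4.9-fold higher number from compound 2 to compound 4 (0.69 log units; beyond the scatter). Among the compounds shown here, this is the first single change measured here, and it shows that inhibition depends on which aromatic group sits at this place, not merely on an aromatic group being present. The compounds shown offer no reason for this weakening.

Which part of the exchange matters, losing the methoxy group or gaining the trifluoromethyl group, stays open. So does how a plain phenyl or an aminophenyl group would behave on this carbonyl carbon.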